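Notes on the 1-phenylethyl analogue of compound 2

The source may hold more compounds than are shown below. What is called first, only, known or untested is meant among the compounds shown, and "the series" means these compounds.

Compound 2 `CCCn1c(=O)[nH]c2nc(-c3ccc(S(=O)(=O)N4CCN(c5cccc(Br)c5)CC4)cc3)[nH]c2c1=O` is the lower of the two compounds measured in an assay on CHO cells for displacement of a labelled ligand from adenosine receptor A1 (Homo sapiens), read by scintillation counting, with a stated time of 90 min, tested at 1 uM, in the presence of a further agent that is not named here; a higher number here means more inhibition at the concentration tested (going by the name of the read-out), a lower number less inhibition; in this assay compound 2 gives -1%. Among the measured compounds shown here, compound 1 `CCCn1c(=O)[nH]c2nc(-c3ccc(S(=O)(=O)N4CCN(c5ccc(Br)cc5)CC4)cc3)[nH]c2c1=O` gives 13% in this assay, and the only step measured so far, a number 14 percentage points lower from compound 1 to compound 2 (beyond the scatter), is a 3-bromophenyl in place of 4-bromophenyl on an amine nitrogen in a ring, leaving the kind of group at that nitrogen unchanged. Compound 3 `CCCn1c(=O)[nH]c2nc(-c3ccc(S(=O)(=O)N4CCN(C(C)c5ccccc5)CC4)cc3)[nH]c2c1=O` is not yet measured. It differs from compound 2 thus: 1-phenylethyl in place of 3-bromophenyl on an amine nitrogen in a ring. For the measured compounds named here, no measured step exchanges an aromatic group for a 1-phenylethyl at this nitrogen, so the one available step bears only indirectly; it shows that a change at this position shifted inhibition by a number 14 percentage points lower from compound 1 to compound 2 (beyond the scatter), a modest amount. Both measured numbers are low, and nothing in them points to a large rise for a new group here. The expected step is a number 6 percentage points higher from compound 2 to compound 3 (within the scatter), which is taken to lie around the scatter in either direction. Compound 3 is estimated at 5% in this assay, with a range from -10% to 25%.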

Compound 3, a percentage reported as inhibition, at one concentration (the size of the read-out at that concentration, not a potency): 42%
Compound 3: middle estimate off by 37 percentage points, on the low side; the whole stated range lies below it.
By their numbers in this assay, from the lowest: compound 2; then compound 1; then compound 3.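

At this nitrogen on the ring, the kind of group matters more than the two bromophenyl compounds could show: in this assay the change to 1-phenylethyl gives a number 43 percentage points higher from compound 2 to compound 3 (beyond the scatter) and, from the other bromophenyl, a number 29 percentage points higher from compound 1 to compound 3 (beyond the scatter). Both steps go the same way and both exceed the shift seen on moving the bromine, a number 14 percentage points lower from compound 1 to compound 2 (beyond the scatter), so the low numbers of the two bromophenyl compounds do not set a ceiling for this position. No measurement at hand offers a reason for the rise.

The change to 1-phenylethyl keeps the six-membered aromatic ring but removes the bromine and alters how that ring is joined to the nitrogen, and the compounds shown cannot separate these contributions; an unsubstituted phenyl, a benzyl or a bromine-bearing 1-phenylethyl at this nitrogen would pull them apart. As far as these compounds go, the read-out is also taken at a single concentration, so how far compound 3 stands from the bromophenyl compounds in potency stays open, as does whether larger groups than 1-phenylethyl, such as a diphenylmethyl, would carry the rise further.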